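The compounds below may be only part of what the source reports. "The series", "measured", "known", "first", "only" and "open" are said of these compounds alone.

Among the compounds with values here, in a functional assay (Platelet, plasma) for inhibition, with Homo sapiens as the target (on this read-out lower numbers stand for stronger inhibition and higher numbers for weaker inhibition), compound 2 (`N#Cc1cc2c(nc1N1CCC(C(=O)NS(=O)(=O)c3ccc(Cl)s3)CC1)COC2=O`) gives 4470 nM, the lower of the two numbers so far, while compound 1 (`N#Cc1cc2c(nc1N1CCC(F)(C(=O)NS(=O)(=O)c3ccc(Cl)s3)CC1)COC2=O`) gives 37100 nM. Compound 3 (`CC1OC(=O)c2cc(C#N)c(N3CCC(C(=O)NS(=O)(=O)c4ccc(Cl)s4)CC3)nc21`) has one change from compound 2: methyl in place of hydrogen on a saturated ring carbon. This is methyl in place of hydrogen on a saturated ring carbon of a five-membered non-aromatic ring, next to the ring oxygen.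

Within the data shown here, the only measured step is an 8.3-fold lower number from compound 1 to compound 2 (0.92 log units; beyond the scatter). It is hydrogen in place of fluoro at a different place in the molecule, so it shows that one replacement on a saturated ring carbon can move this read-out beyond the scatter. Among the measured compounds shown here, it gives no direct guide to the size or direction for methyl, and no measured compound carries this group. The best guess is therefore no step beyond the scatter, with a wide range on both sides. The estimated step is a 1.1-fold higher number from compound 2 to compound 3 (0.05 log units; within the scatter). For compound 3 the expected value is 5000 nM, with an estimated range of 1500 nM to 15000 nM.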

Compound 3, half-maximal inhibitory concentration: > 300000 nM
Compound 3 ended at the assay's limit; the forecaster's own chance of this, stated with the estimate: 3%; middle value at least 60-fold (1.77 log units) from the limit.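

Methyl in place of hydrogen on a saturated ring carbon, next to the ring oxygen, gives an at least 67-fold higher number from compound 2 to compound 3 (1.82 log units; beyond the scatter) in this assay. Compound 1 and compound 2 showed only that a replacement elsewhere in the molecule can move this read-out; this step shows that this ring carbon itself tolerates a single added methyl poorly, with hydrogen the better of the two groups compared here. The reading for compound 3 is a limit of the assay and not a number: the limit of > 300000 nM in this assay, at which 1 of the 3 values shown sits.

From the compounds shown here alone, the true size of this step therefore stays unknown. Also open, going by these compounds, is whether any group on this carbon weakens inhibition in this way or whether the effect is specific to methyl, as a fluoro, a hydroxyl or a longer chain such as ethyl at the same place would show.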